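Swapping chloro for amino: an expected loss of cytotoxicity

This account rests on a few compounds, and the source may have more. Where it says the series, first, only, none or still open, it means among the compounds named here.

In a functional assay on NCI-H226 cells (Homo sapiens) for cytotoxicity, read by sulforhodamine B assay, with a stated time of 48 h (on this read-out lower numbers stand for higher toxicity in this test and higher numbers for lower toxicity in this test), the measured compounds gave:
Compound 1 `Nc1nc(Cl)c2ncn(Cc3ccc(CCl)cc3)c2n1`: > 100000 nM, a limit of the assay.
Compound 2 `ClCc1cccc(Cn2cnc3c(Cl)nc(Cl)nc32)c1`: 40700 nM.
Compound 3 `ClCc1ccc(Cn2cnc3c(Cl)nc(Cl)nc32)cc1`: 33900 nM.

Compound 2 and compound 3 are built from the same atoms joined differently; the difference between the two cores is not broken down here. In this assay their numbers lie within the usual scatter of each other. One change is seen twice. From compound 3 to compound 1, (amino in place of chloro on an aromatic carbon), it gave an at least 2.9-fold higher number from compound 3 to compound 1 (0.46 log units; beyond the scatter); the number for compound 1 is a limit (the limit of > 100000 nM in this assay, at which 1 of the 3 values shown sits). Compound 4 `Nc1nc(Cl)c2ncn(Cc3cccc(CCl)c3)c2n1` carries the same change relative to compound 2, (amino in place of chloro on an aromatic carbon), at a place described in the same words. Resting on an at least 2.9-fold higher number from compound 3 to compound 1 (0.46 log units; beyond the scatter), the expected step is a 2.9-fold higher number from compound 2 to compound 4 (0.47 log units; beyond the scatter). Compound 4 is therefore estimated at 120000 nM, likely reported only as a limit, spanning 60000 nM to 300000 nM.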

Compound 4, concentration lethal to 50% of the cells: > 100000 nM
Compound 4 gave a limit, no number; the forecaster's own chance of this, stated with the estimate: 70%; the middle value does not contradict the limit.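

In this assay, amino in place of chloro on an aromatic carbon gave an at least 2.4-fold higher number from compound 2 to compound 4 (0.39 log units; beyond the scatter). Set beside the earlier step, the change points the same way on both cores, but its size cannot be compared between them: the same change on two cores in this assay, an at least 2.9-fold higher number (0.46 log units; beyond the scatter) from compound 3 to compound 1 and an at least 2.4-fold higher number (0.39 log units; beyond the scatter) from compound 2 to compound 4; the limit leaves it open whether they differ. Going by these compounds, compound 1 and compound 4 both stand at a limit rather than a number, so the true size of the step on either core stays unknown: the limit of > 100000 nM in this assay, at which 2 of the 4 values shown sit.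

The compounds shown leave open where a methoxy group or a methylamino group in the same place would fall in this assay. They also leave open whether such a group would give a measurable number rather than a limit.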